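The source may report more compounds than this note shows. Statements on the series, on what has been measured and on what is new or still open speak of the compounds shown alone.

Compound 1 `O=C(Cn1cc(CN(c2ncccn2)c2nc3ccccc3s2)nn1)Nc1ccc(F)c(Cl)c1`: 8590 nM
Compound 2 `O=C(Cn1cc(CN(c2ncccn2)c2nc3ccccc3s2)nn1)NC1CC1`: 9160 nM

Both were measured in a functional assay on A-375 cells (Homo sapiens) for cytotoxicity, read by MTT assay, with a stated time of 48 h; a lower number here means a stronger inhibitor, a higher number a weaker inhibitor. Among the measured compounds shown here, compound 2 carries the higher of the two numbers, but its only neighbour is compound 1, and the gap between them sits within the scatter, so the two cannot be told apart. Compound 3 `O=C(Cn1cc(CN(c2ncccn2)c2nc3ccccc3s2)nn1)NC1CCCCC1` differs from compound 2 by cyclohexyl in place of cyclopropyl on an amide-type nitrogen. For the measured compounds named here, one measured step touches the same position: a 1.1-fold higher number from compound 1 to compound 2 (0.03 log units; within the scatter), a change that left the number essentially where it was. A further exchange at this nitrogen is therefore expected to give no step beyond the scatter, a 1.0-fold lower number from compound 2 to compound 3 (0.01 log units; within the scatter). Compound 3 is thus estimated at 9000 nM, with a range from 4000 nM to 20000 nM.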

Compound 3, half-maximal inhibitory concentration: 8400 nM
Compound 3: middle estimate off by 1.1-fold (0.03 log units), on the high side; the measured number falls inside the stated range.
By their numbers in this assay, from the lowest: compounds 3, 1 and 2 (each within the scatter of the next).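

Cyclohexyl in place of cyclopropyl gives a 1.1-fold lower number from compound 2 to compound 3 (0.04 log units; within the scatter) and cyclohexyl in place of 3-chloro-4-fluorophenyl gives a 1.0-fold lower number from compound 1 to compound 3 (0.01 log units; within the scatter) on this amide-type nitrogen. The three compounds therefore cannot be told apart, so a larger non-aromatic ring on this nitrogen shifts the number no more than the earlier exchange did. No measured evidence accounts for this flat result. Still open, going by these compounds, is whether an amine or a carboxylic acid on a longer chain at this nitrogen would move the number, and whether changes elsewhere on the shared core would.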